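This account rests on a few compounds, and the source may have more. Where it says the series, first, only, none or still open, it means among the compounds named here.

Of the compounds shown here, three have been tested in a toxicity assay on Huh-7.5 cells (Homo sapiens) for inhibition, read by MTT assay, with a stated time of 96 h; on this read-out lower numbers stand for higher toxicity in this test and higher numbers for lower toxicity in this test. Compound 1, `CN(C)C1CCN(Cc2ccc(NC(=O)c3ccc(OCCCCl)c([N+](=O)[O-])c3)cc2C(F)(F)F)C1`, gives 5800 nM. Compound 2, `CN1CCN(Cc2ccc(NC(=O)c3ccc(OCCCCl)c(Cl)c3)cc2C(F)(F)F)CC1`, gives 4100 nM. Compound 3, `CN1CCN(Cc2ccc(NC(=O)c3ccc(OCCCCCl)c([N+](=O)[O-])c3)cc2C(F)(F)F)CC1`, gives 3740 nM. The three numbers lie close together: the gap from compound 3 to compound 2 and the gap from compound 3 to compound 1 are both within the usual scatter of repeated measurements, so none of the three can be set apart from the others on this read-out. Compound 3 is the starting point for the next step.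

Compound 4 is `CN1CCN(Cc2ccc(NC(=O)c3ccc(OCCCCl)c([N+](=O)[O-])c3)cc2C(F)(F)F)CC1`. It has not yet been measured. The change from compound 3 to compound 4 is chloro in place of chloromethyl on a saturated chain carbon, three bonds along the chain from an oxygen on an aromatic ring. The chain that carries the chlorine at its end is thereby one carbon shorter, while the rest of the shared core, the nitro group and the amine-bearing side are unchanged.

For the measured compounds named here, no pair of measured compounds differs in only one place, so no directly comparable step is available. Since the three measured numbers themselves spread no further than the scatter, a step in this assay that stays within the scatter, with no clear direction, is the expectation here. Compound 4 is thus estimated at 4300 nM, with a likely range from 2100 nM to 8800 nM, which amounts to an expected step of a 1.1-fold higher number from compound 3 to compound 4 (0.06 log units; within the scatter).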

Compound 4, half-maximal cytotoxic concentration: 6800 nM
Compound 4: the middle estimate sits 1.6-fold (0.20 log units) below what was measured; measured number inside the range.
By their numbers in this assay, from the lowest: compounds 3, 2, 1 and 4 (each within the scatter of the next).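

Three single changes can now be read in this assay, and each stays within the scatter: 4-chlorobutyl to 3-chloropropyl on the chain attached through the oxygen on an aromatic ring (a 1.8-fold higher number from compound 3 to compound 4 (0.26 log units; within the scatter)), nitro in place of chloro on an aromatic carbon (a 1.7-fold higher number from compound 2 to compound 4 (0.22 log units; within the scatter)), and 4-methylpiperazin-1-yl in place of 3-(dimethylamino)pyrrolidin-1-yl on a saturated chain carbon bound to an aromatic carbon (a 1.2-fold higher number from compound 1 to compound 4 (0.07 log units; within the scatter)). For these four compounds, then, the number on this read-out cannot be told apart from repeat-measurement scatter when the chain end, the aromatic group or the amine is exchanged in these ways. Nothing measured here offers an explanation for these numbers, and with no step beyond the scatter there is also no difference to explain.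

On these data alone, whether any change at the chain position can move the number clearly remains open, for example a plain propyl chain with no chlorine, a carboxylic acid at the chain end, or a much longer chain. The same holds for the other two places, where a nitrile in place of nitro or a morpholine in place of 4-methylpiperazin-1-yl would be further tests.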